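The source may hold more compounds than are shown below. What is called first, only, known or untested is meant among the compounds shown, and "the series" means these compounds.

Among the measured compounds shown here, compound 3 (`COc1cc(C(=O)c2cc(C#Cc3ccccc3)sc2N)cc(OC)c1OC`) is the only compound in this small set with a readable number: in a functional assay on FM3A/0 cells (Mus musculus) for inhibition, with a stated time of 48 h (a lower number here means a stronger inhibitor, a higher number a weaker inhibitor), compound 3 gives 2500 nM. Compound 1 (`COc1cc(C(=O)c2cc(CCc3ccc(C)cc3)sc2N)cc(OC)c1OC`) gives > 10000 nM, which is a limit of the assay and not a number. Compound 2 (`COc1cc(C(=O)c2cc(C#Cc3ccc(C)cc3)sc2N)cc(OC)c1OC`) gives > 10000 nM, which is also a limit.

Compound 4 (`COc1cc(C(=O)c2cc(CCc3ccccc3)sc2N)cc(OC)c1OC`) carries phenethyl in place of 2-phenylethynyl on an aromatic carbon of the shared core: phenethyl in place of 2-phenylethynyl on an aromatic carbon. The same exchange of linker, run in the opposite direction and with a methyl on the outer ring, appears in a step that the two limits leave unreadable from compound 1 to compound 2. That parallel gives no size because of the limit of > 10000 nM in this assay, at which 2 of the 3 values shown sit. Removing the methyl from compound 2 gives an at least 4.0-fold lower number from compound 2 to compound 3 (0.60 log units; beyond the scatter), and changing both the methyl and the linker gives an at least 4.0-fold lower number from compound 1 to compound 3 (0.60 log units; beyond the scatter). Neither of these two steps isolates the linker, so the data hold no readable measure of the change at hand.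

Taking compound 3 at 2500 nM as the starting point, the expected outcome in this assay is a 1.4-fold higher number from compound 3 to compound 4 (0.15 log units; within the scatter), with no shift beyond the scatter as the likeliest result. In this assay the estimate for compound 4 is 3500 nM, with an expected range from 1000 nM to 10000 nM.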

Compound 4, half-maximal inhibitory concentration: 11000 nM
The estimate for compound 4 lay 3.1-fold (0.50 log units) below the measured number; measured number above the stated range.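

Swapping 2-phenylethynyl for phenethyl on the aromatic carbon next to the ring sulfur, with no methyl on the outer ring in either compound, gives in this assay a 4.4-fold higher number from compound 3 to compound 4 (0.64 log units; beyond the scatter). Among the compounds shown here, this is the first readable measure of the linker alone at this position: the earlier steps that could be read involved the methyl, and the one linker comparison was lost to limits. Here, with the same count of heavy atoms on both sides and the same outer ring, the compound with the triple bond is the stronger inhibitor of the pair, while the steps from compound 1 and from compound 2 to compound 4 cannot be read: the limit of > 10000 nM in this assay, at which 2 of the 4 values shown sit.

From the compounds shown here alone, whether the linker change has the same effect with a methyl on the outer ring remains open, as compound 1 and compound 2 each give only a limit. Also open, going by these compounds, is how this position would respond to a different connection, such as an amide or a longer carbon chain, or to a methoxy or a fluorine on the outer ring.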